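A few compounds are considered here, and "the series" means these few. Any claim that something is new, unique, unknown or untested is made for them only; others in the source may bear on it.

Measured compounds in an ADME assay on LLC-MK2 cells (Macaca mulatta) for cytotoxicity, read by spectrophotometry and crystal violet staining, with a stated time of 4 days; a higher number here means that more compound is tolerated, a lower number that less compound is tolerated:
compound 1, `CC(C)n1ncc2c(C(=O)Nc3ccccn3)cc(C3CC3)nc21`: 25000 nM
compound 2, `CC(C)n1ncc2c(C(=O)Nc3ccc(F)c(F)c3)cc(-c3cccs3)nc21`: a limit, > 200000 nM
compound 3, `CC(C)n1ncc2c(C(=O)Nc3ccc(F)c(S(N)(=O)=O)c3)cc(-c3cccs3)nc21`: 50000 nM

Compound 2 stands only as a limit in this assay, > 200000 nM, and no number is reported for it; this is the situation noted in the limit of > 200000 nM in this assay, at which 1 of the 3 values shown sits. Among the measured compounds shown here, compound 3 gives 50000 nM in this assay, so the step of an at least 4.0-fold lower number from compound 2 to compound 3 (0.60 log units; beyond the scatter) is the one measured step. Compound 2 and compound 3 differ only in one group on the ring attached to the amide nitrogen. For the measured compounds named here, compound 1, which carries a different ring at the amide nitrogen and a different group on the shared core, gives 25000 nM in this assay; no single-place step links it to the other two.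

Compound 4, `CC(C)n1ncc2c(C(=O)Nc3ccncn3)cc(-c3cccs3)nc21`, is not yet measured. It differs from compound 2 by pyrimidin-4-yl in place of 3,4-difluorophenyl on an amide-type nitrogen. Going by the values given here, the only measured step that bears on it is an at least 4.0-fold lower number from compound 2 to compound 3 (0.60 log units; beyond the scatter), likewise a change of the ring on the amide nitrogen, and that step went beyond the scatter toward a lower number. A decrease from the limit of compound 2 is therefore expected for compound 4, an at least 2.5-fold lower number from compound 2 to compound 4 (0.39 log units; beyond the scatter). For compound 4 the estimated value in this assay is 80000 nM, with a range from 20000 nM to 200000 nM.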

Compound 4, half-maximal cytotoxic concentration: 50000 nM
Compound 4: middle estimate off by 1.6-fold (0.20 log units), on the high side; the range from low to high includes it.
By their numbers in this assay, from the lowest: compounds 1, 3 and 4 (each within the scatter of the next). At a limit, above all of these: compound 2.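

Replacing the whole 3,4-difluorophenyl on the amide-type nitrogen with pyrimidin-4-yl, a six-membered aromatic ring with 2 hetero atoms, gives an at least 4.0-fold lower number from compound 2 to compound 4 (0.60 log units; beyond the scatter) in this assay, so this position now shows a second change beyond the scatter, and this one alters the ring itself rather than a single group on it. Together with an at least 4.0-fold lower number from compound 2 to compound 3 (0.60 log units; beyond the scatter), both changes at this position that can be read from compound 2 point to a lower number, and no compound shown goes against this, though the pattern rests on these two steps alone; compound 3 gives 50000 nM and compound 4 gives 50000 nM, the same printed value from two different rings. Compound 2 is held only as a limit, so both steps have a floor but no fixed size: the limit of > 200000 nM in this assay, at which 1 of the 4 values shown sits.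

Still open, on these data alone, is what a carboxylic acid or an amine on the ring at the amide nitrogen would do to the number in this assay. Also open, as far as these compounds go, is whether a plain phenyl at this position stays with compound 2 at the limit or comes down to the values of compound 3 and compound 4.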